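Moving the Fluorine on the Anilino Ring

The source may report more compounds than this note shows. Statements on the series, on what has been measured and on what is new or still open speak of the compounds shown alone.

Compound 1 `CCCOc1ccc(C(=O)Nc2cccc(C)n2)cc1` gives 7500 nM in an in vitro assay on HEK-tsA201 cells for antagonist activity at Neuronal acetylcholine receptor; alpha4/beta2 (Homo sapiens), read by fluorescence and calcium flux; a higher number here means a weaker inhibitor, a lower number a stronger inhibitor. Compound 2 `CCCOc1ccc(C(=O)Nc2cccc(Nc3ccccc3)n2)cc1` reaches only a limit of this assay, > 100000 nM. Compound 3 `CCCOc1ccc(C(=O)Nc2cccc(Nc3cccc(F)c3)n2)cc1` likewise gives a limit, > 100000 nM, so its standing is known only as a bound, not as a number. The two measured steps that bear here are an at least 13-fold higher number from compound 1 to compound 2 (1.12 log units; beyond the scatter) and an at least 13-fold higher number from compound 1 to compound 3 (1.12 log units; beyond the scatter); both exchange the methyl of compound 1 for an arylamino group and both run into (the limit of > 100000 nM in this assay, at which 2 of the 3 values shown sit). The fluorine itself gives a step that the two limits leave unreadable from compound 2 to compound 3.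

Compound 4 `CCCOc1ccc(C(=O)Nc2cccc(Nc3ccc(F)cc3)n2)cc1` differs from compound 3 only in 4-fluorophenyl in place of 3-fluorophenyl on a nitrogen on an aromatic ring. Since both arylamino analogues already sit at the limit, nothing in the data suggests that shifting the fluorine will recover activity, and the expected step is a step that the limit leaves unreadable from compound 3 to compound 4, with a result most likely again reported as a limit. The estimate for compound 4 is therefore 150000 nM, within a range of 50000 nM to 500000 nM.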

Compound 4, half-maximal inhibitory concentration: > 100000 nM
Compound 4: a limit, no number (the forecaster's own chance of this, stated with the estimate: 85%); the middle value lies beyond the limit too.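

Moving the fluorine adds one more limit in this assay: compound 4 gives no number, so this position on the anilino ring shows no readable preference between 3-fluorophenyl and 4-fluorophenyl, and the steps among compound 2, compound 3 and compound 4 cannot be read. The exchange of methyl for (4-fluorophenyl)amino gives an at least 13-fold higher number from compound 1 to compound 4 (1.12 log units; beyond the scatter) and so matches the loss already seen for the other two arylamino groups. With a third arylamino analogue in this series, the values now crowd at a single ceiling: the limit of > 100000 nM in this assay, at which 3 of the 4 values shown sit.

From the compounds shown here alone, how far these three compounds lie past that limit stays open. So does whether an ethyl group, a methoxy group or a plain amine in place of the methyl on this aromatic carbon would keep a readable value.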